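Trifluoromethyl to Propyl: A Step Without a Measured Guide

The source may report more compounds than this note shows. Statements on the series, on what has been measured and on what is new or still open speak of the compounds shown alone.

Of the compounds shown here, three sharing one core have been tested in a functional assay on MCF7 cells (Homo sapiens) for inhibition, read by sulforhodamine B assay; on this read-out lower numbers stand for stronger inhibition and higher numbers for weaker inhibition. Compound 1 `O=C1C(Nc2ccccc2)=CC(=O)c2c1nc1n2[C@H]2OC[C@@H](O)[C@H]2OC1` reports only a limit, > 4000 nM. Compound 3 `O=C1C(Nc2ccc(C(F)(F)F)cc2)=CC(=O)c2c1nc1n2[C@H]2OC[C@@H](O)[C@H]2OC1` likewise reports only a limit, > 4000 nM, so it has no fixed place on the scale. Among the compounds with values here, compound 2 `O=C1C(Nc2ccc(Br)cc2)=CC(=O)c2c1nc1n2[C@H]2OC[C@@H](O)[C@H]2OC1` gives the one true number, 4330 nM.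

Compound 4 `CCCc1ccc(NC2=CC(=O)c3c(nc4n3[C@H]3OC[C@@H](O)[C@H]3OC4)C2=O)cc1` has propyl in place of trifluoromethyl on an aromatic carbon, para to a large group (propyl in place of trifluoromethyl on an aromatic carbon). The measured changes at this position offer no size to carry over: there is a step that the limit leaves unreadable from compound 1 to compound 2, a step that the two limits leave unreadable from compound 1 to compound 3 and a step that the limit leaves unreadable from compound 2 to compound 3. The background is the limit of > 4000 nM in this assay, at which 2 of the 3 values shown sit.

With no readable step to draw on, no step beyond the scatter is expected, and no direction is favoured. The expected change is a step that the limit leaves unreadable from compound 3 to compound 4. Within the data shown here, the estimate leans on compound 2 at 4330 nM, the only number available. For compound 4 the expected value is 4200 nM, within an estimated range of 1800 nM to 10000 nM.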

Compound 4, half-maximal inhibitory concentration: > 4000 nM
Compound 4: a limit, no number; the forecaster's own chance of this, stated with the estimate: 50%; the middle value is on the limit's open side.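

In this assay compound 4 reports only a limit, > 4000 nM, so its steps to compound 1, compound 2 and compound 3 cannot be read. The compounds shown leave open whether any group at this position changes inhibition by a readable size, with most values resting on a single limit: the limit of > 4000 nM in this assay, at which 3 of the 4 values shown sit.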